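Acrylamide-bearing quinazoline thioacetamides against NCI-H1975 cells

The source may report more compounds than this note shows. Statements on the series, on what has been measured and on what is new or still open speak of the compounds shown alone.

Measured compounds:
compound 1, `COc1cccc(NC(=O)CSc2nc(Nc3ccccc3)c3ccccc3n2)c1`: 19400 nM
compound 2, `O=C(CSc1nc(Nc2ccccc2)c2ccccc2n1)Nc1ccc(F)cc1`: 16500 nM
compound 3, `C=CC(=O)Nc1cccc(NC(=O)CSc2nc(Nc3cccc(OC)c3)c3ccccc3n2)c1`: 7940 nM

In a functional assay on NCI-H1975 cells (Homo sapiens) for inhibition, read by MTT assay, with a stated time of 72 h (on this read-out lower numbers stand for stronger inhibition and higher numbers for weaker inhibition), compound 1 gives 19400 nM and compound 2 gives 16500 nM. The two are separated by 4-fluorophenyl in place of 3-methoxyphenyl on an amide-type nitrogen; the resulting step, a 1.2-fold lower number from compound 1 to compound 2 (0.07 log units; within the scatter), is within the scatter, so no order between them is claimed. Compound 3 gives 7940 nM, the lowest of the three numbers, with both gaps to compound 1 and compound 2 beyond the scatter. The difference between the core of compound 3 and the core of compound 1 is not broken down here.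

Compound 4, `C=CC(=O)Nc1cccc(NC(=O)CSc2nc(Nc3ccc(F)cc3)c3ccccc3n2)c1`, is not yet measured. It differs from compound 3 by 4-fluorophenyl in place of 3-methoxyphenyl on a nitrogen on an aromatic ring. The same kind of change was made from compound 1 to compound 2, but there it sat on an amide-type nitrogen whose other neighbour is a carbonyl carbon, whereas here it sits on a nitrogen on an aromatic ring whose other neighbour is an aromatic carbon. Because the earlier step, a 1.2-fold lower number from compound 1 to compound 2 (0.07 log units; within the scatter), was small, a step of similar size is expected, a 1.2-fold lower number from compound 3 to compound 4 (0.08 log units; within the scatter). Compound 4 is therefore estimated at 6600 nM, within 3000 nM to 14000 nM.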

Compound 4, half-maximal inhibitory concentration: 4430 nM
For compound 4 the middle estimate is 1.5-fold (0.17 log units) above the measured one; the range from low to high includes it.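

In this assay, 4-fluorophenyl in place of 3-methoxyphenyl on a nitrogen on an aromatic ring gives a 1.8-fold lower number from compound 3 to compound 4 (0.25 log units; within the scatter), so no order is claimed within this pair. Set beside the same change at the amide-type nitrogen on the other core, this step does not differ from the earlier one: the same change on two cores in this assay, a 1.2-fold lower number (0.07 log units; within the scatter) from compound 1 to compound 2 and a 1.8-fold lower number (0.25 log units; within the scatter) from compound 3 to compound 4, 1.5-fold (0.18 log units) apart, within the scatter of two such steps

On these two pairs, the exchange carries from one core to the other with neither step beyond the scatter, which fits a small effect in both places; it does not show that the exchange is truly neutral, that the two steps are identical, or that the same would hold on any further core.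

As far as these compounds go, whether a larger step appears with other replacements remains open, for example a carboxylic acid, a morpholine or a dimethylamino group on the aryl ring in place of the fluorine or methoxy group. Also open, from the compounds shown here alone, is whether a longer chain between the sulfur and the amide carbonyl would leave this exchange just as small.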